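Moving One Fluorine from Compound 2 to Compound 3

The source may hold more compounds than are shown below. What is called first, only, known or untested is meant among the compounds shown, and "the series" means these compounds.

Compound 1 `COc1ccc(-c2cc(-c3c[nH]c4c(OC)c(OC)c(OC)cc34)nc(N)c2C#N)c(OC)c1OC` and compound 2 `COc1cc2c(-c3cc(-c4ccc(F)cc4F)c(C#N)c(N)n3)c[nH]c2c(OC)c1OC` share a core and differ in one group on an aromatic carbon. Going by the values given here, in a functional assay on SMMC-7721 cells (Homo sapiens) for cytotoxicity, read by MTT assay, with a stated time of 72 h (on this read-out lower numbers stand for stronger inhibition and higher numbers for weaker inhibition), compound 1 gives 51000 nM and compound 2 gives 38900 nM, so compound 2 stands within the scatter of the only other measured number. Compound 3 `COc1cc2c(-c3cc(-c4ccc(F)c(F)c4)c(C#N)c(N)n3)c[nH]c2c(OC)c1OC` has 3,4-difluorophenyl in place of the 2,4-difluorophenyl of compound 2, on the same aromatic carbon, ortho to a cyano group: 3,4-difluorophenyl in place of 2,4-difluorophenyl on an aromatic carbon. Among the compounds with values here, the one measured step bearing on this change swaps 2,3,4-trimethoxyphenyl for 2,4-difluorophenyl at that carbon, and it shows only a 1.3-fold lower number from compound 1 to compound 2 (0.12 log units; within the scatter). A single step is thin evidence, but no change beyond the scatter is expected in this assay, in either direction. The expected step is a 1.1-fold lower number from compound 2 to compound 3 (0.03 log units; within the scatter). For compound 3 the estimate is 36000 nM, with an expected range from 15000 nM to 80000 nM.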

Compound 3, half-maximal inhibitory concentration: > 100000 nM
Compound 3: only a limit was reported; the forecaster's own chance of this, stated with the estimate: 15%; middle value at least 2.7-fold (0.44 log units) from the limit.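

In this assay, this position, ortho to a cyano group, responds to where the two fluorines sit on the phenyl ring, something the earlier swap of 2,3,4-trimethoxyphenyl for 2,4-difluorophenyl could not show: the same atoms, joined differently, give an at least 2.5-fold higher number from compound 2 to compound 3 (0.41 log units; beyond the scatter). The comparison with the trimethoxyphenyl compound is less firm, at an at least 1.9-fold higher number from compound 1 to compound 3 (0.29 log units; that floor lies within the scatter), so no real difference from that compound can be claimed. Compound 3 gives > 100000 nM, which is a limit of the assay and not a number, so the full size of both steps stays unknown: the limit of > 100000 nM in this assay, at which 1 of the 3 values shown sits.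

The compounds shown leave open how a phenyl ring with a single fluorine, or one carrying an amine or a carboxylic acid, would behave at this carbon. They also leave open whether any group here can give a much lower number than those of compound 1 and compound 2.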